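The source may hold more compounds than are shown below. What is called first, only, known or untested is meant among the compounds shown, and "the series" means these compounds.

In a functional assay on HeLa cells (Homo sapiens) for antiproliferative activity, read by MTT assay, with a stated time of 12 h (on this read-out lower numbers stand for stronger inhibition and higher numbers for weaker inhibition), compound 2 `COc1cc(OC)c2c(=O)cc(/C=C/c3ccncc3)oc2c1` gives 18800 nM, the largest of the three numbers shown, though neither neighbour differs from it beyond the scatter: compound 3 `COc1cc(OC)c2c(=O)cc(/C=C/c3ccc(F)cc3)oc2c1` gives 14200 nM and compound 1 `COc1cc(OC)c2c(=O)cc(/C=C/c3ccc([N+](=O)[O-])cc3)oc2c1` gives 9600 nM. Compound 4 `COc1cc(OC)c2c(=O)cc(/C=C/c3ccc(Br)cc3)oc2c1` differs from compound 2 in one place: 4-bromophenyl in place of pyridin-4-yl on a double-bonded chain carbon bound to a double-bonded chain carbon. Among the compounds with values here, two measured steps bear on this. One is a 1.3-fold lower number from compound 2 to compound 3 (0.12 log units; within the scatter), the same exchange of the pyridin-4-yl for a halogen-bearing phenyl at the same place. The other is a 1.5-fold higher number from compound 1 to compound 3 (0.17 log units; within the scatter), an exchange between two groups on the aromatic carbon of that phenyl. Both stay within the scatter, so no step beyond the scatter is expected for compound 4, namely a 1.3-fold lower number from compound 2 to compound 4 (0.13 log units; within the scatter). Compound 4 is therefore estimated at 14000 nM, with a range from 7000 nM to 28000 nM.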

Compound 4, half-maximal inhibitory concentration: > 40000 nM
Compound 4: a limit, no number (the forecaster's own chance of this, stated with the estimate: 5%); middle value at least 2.8-fold (0.45 log units) from the limit.
By their numbers in this assay, from the lowest: compounds 1, 3 and 2 (each within the scatter of the next). At a limit, above all of these: compound 4.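

In this assay compound 4 gives > 40000 nM, which is a limit of the assay and not a number. Unlike the earlier steps, the exchange of pyridin-4-yl for 4-bromophenyl on this double-bonded chain carbon goes beyond the scatter, with an at least 2.1-fold higher number from compound 2 to compound 4 (0.32 log units; beyond the scatter). The group on the aromatic carbon also matters, since bromo separates from fluoro, with an at least 2.8-fold higher number from compound 3 to compound 4 (0.44 log units; beyond the scatter), and from nitro, with an at least 4.1-fold higher number from compound 1 to compound 4 (0.61 log units; beyond the scatter), although fluoro and nitro lie within the scatter of each other.

Going by these compounds, what chloro, methoxy or an amine would give on that aromatic carbon stays open. So does whether bromo stands alone or sits at the end of a gradual trend.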